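A Fluoro-to-Chloro Swap Read Across Two Benzyl Positions

The source may hold more compounds than are shown below. What is called first, only, known or untested is meant among the compounds shown, and "the series" means these compounds.

Compound 1 `CN(Cc1cccc(F)c1)C(=O)c1cc2c(Cc3ccccc3)n[nH]c2cc1O` and compound 2 `CN(Cc1cccc(Cl)c1)C(=O)c1cc2c(Cc3ccccc3)n[nH]c2cc1O` share a core and differ only by chloro in place of fluoro on an aromatic carbon. In a functional assay on A2780 cells (Homo sapiens) for antiproliferative activity, read by resazurin assay, with a stated time of 72 h (a higher number here means a weaker inhibitor, a lower number a stronger inhibitor), compound 1 gives 5000 nM, and compound 2 gives 5300 nM, so the change made a 1.1-fold higher number from compound 1 to compound 2 (0.03 log units; within the scatter). Compound 3 `CN(Cc1ccccc1)C(=O)c1cc2c(Cc3cccc(F)c3)n[nH]c2cc1O` carries the same atoms joined differently; the difference between the two cores is not broken down here. In this assay compound 3 gives 1700 nM, the lowest number of the three. Compound 4 `CN(Cc1ccccc1)C(=O)c1cc2c(Cc3cccc(Cl)c3)n[nH]c2cc1O` is not yet measured and differs from compound 3 by chloro in place of fluoro on an aromatic carbon, the same change as before. The step expected is a 1.1-fold higher number from compound 3 to compound 4 (0.02 log units; within the scatter), because a 1.1-fold higher number from compound 1 to compound 2 (0.03 log units; within the scatter) stayed within the scatter. Compound 4 is therefore estimated at 1800 nM, between 900 nM and 3600 nM.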

Compound 4, half-maximal inhibitory concentration: 410 nM
Estimate against measurement, compound 4: 4.4-fold (0.64 log units) above; the whole stated range lies above it.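

In this assay the change from 3-fluorobenzyl to 3-chlorobenzyl on the core of compound 3 gave a 4.1-fold lower number from compound 3 to compound 4 (0.62 log units; beyond the scatter). The same change therefore did not carry over from one core to the other with the same size: the same change on two cores in this assay, a 1.1-fold higher number (0.03 log units; within the scatter) from compound 1 to compound 2 and a 4.1-fold lower number (0.62 log units; beyond the scatter) from compound 3 to compound 4, 4.4-fold (0.64 log units) apart, beyond the scatter of two such steps. This shows that, for these two cores, the step measured on one did not predict the step on the other; it does not show why the two steps differ, and two pairs set no rule for any further core.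

The compounds shown leave open whether a bromo or a methoxy on the same aromatic carbon would give a step like that to compound 4. They also leave open what chloro on both benzyl groups would give.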